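The source may hold more compounds than are shown below. What is called first, only, known or untested is meant among the compounds shown, and "the series" means these compounds.

Measured in a functional assay on JeKo-1 cells (Homo sapiens) for antiproliferative activity; a higher number here means a weaker inhibitor, a lower number a stronger inhibitor:
compound 1 `Nc1ncnc2c1c(-c1cc3ccccc3o1)cn2[C@H]1CCN(C[C@H]2CO2)C1`: 630 nM
compound 2 `Nc1ncnc2c1c(-c1ccc(Oc3ccccc3)cc1)cn2[C@H]1CCN(C[C@H]2CO2)C1`: 5080 nM
compound 3 `CC(C)(C)c1ccc(C(=O)Nc2ccc(-c3cn([C@H]4CCN(C[C@@H]5CO5)C4)c4ncnc(N)c34)cc2)cc1`: 3290 nM

Compound 3 holds the second highest of the three numbers in this assay. Its nearest neighbour is compound 2, which sits within the scatter of it; compound 1 stands well lower, beyond the scatter. Compound 4 `Nc1ncnc2c1c(-c1ccc(NC(=O)c3ccccc3)cc1)cn2[C@H]1CCN(C[C@@H]2CO2)C1` keeps the whole of compound 3 apart from one change at the benzoyl end: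

hydrogen in place of tert-butyl on an aromatic carbon

Among the compounds with values here, no measured pair shows this kind of change, so there is no step to lean on. Stripping the tert-butyl from the outer ring is expected to move the number little, if at all, in this assay: the step of a 1.1-fold lower number from compound 3 to compound 4 (0.04 log units; within the scatter) is estimated to lie within the scatter, with no firm direction. Compound 4 is therefore expected to give about 3000 nM in this assay, in a range from 1200 nM to 8000 nM.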

Compound 4, half-maximal inhibitory concentration: 5390 nM
Estimate against measurement, compound 4: 1.8-fold (0.25 log units) below, within the range that was stated.
By their numbers in this assay, from the lowest: compound 1; then compounds 3, 2 and 4 (each within the scatter of the next).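

In this assay, hydrogen in place of tert-butyl on an aromatic carbon, para to a large group, gives a 1.6-fold higher number from compound 3 to compound 4 (0.21 log units; within the scatter), the first step read at this position. The 4-(tert-butyl)phenyl and phenyl ends are thus not told apart in this assay, so the tert-butyl is not needed to hold the number at this level. Nothing at hand bears on the reason for this result.

On these data alone, whether an amine, a carboxylic acid or a longer alkyl chain at this carbon would move the number beyond the scatter remains open.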